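A Methyl Group in Place of Cyano

The source may hold more compounds than are shown below. What is called first, only, known or untested is meant among the compounds shown, and "the series" means these compounds.

In a functional assay on MCF7 cells (Homo sapiens) for cytotoxicity, read by CellTiter-Glo, with a stated time of 5 days (on this read-out higher numbers stand for weaker inhibition and lower numbers for stronger inhibition), compound 1 (`CC/C(=C(/c1ccc(/C=C/C(=O)O)c(OC)c1)c1ccc2[nH]ncc2c1)c1ccccc1`) gives 31 nM and compound 2 (`CC/C(=C(/c1ccc(/C=C/C(=O)O)cc1)c1ccc2[nH]ncc2c1)c1ccccc1Cl`) gives 2 nM while compound 3 (`CC/C(=C(/c1ccc(/C=C/C(=O)O)cc1)c1ccc2[nH]ncc2c1)c1ccccc1C#N`) gives 12 nM on the same read-out. Compound 3 thus holds the second highest of the three numbers, lower than compound 1 and higher than compound 2, with both gaps beyond the usual scatter. The step followed here leads to compound 4 (`CC/C(=C(/c1ccc(/C=C/C(=O)O)cc1)c1ccc2[nH]ncc2c1)c1ccccc1C`), which carries methyl in place of cyano on an aromatic carbon, ortho to a large group, the change from 2-cyanophenyl to 2-methylphenyl (methyl in place of cyano on an aromatic carbon). No methyl at this place has been measured yet, and compound 1 differs from compound 3 in more than one place, so it offers no clean comparison. Among the measured compounds shown here, one measured step touches the same place. Since cyano in place of chloro gave a 6.0-fold higher number from compound 2 to compound 3 (0.78 log units; beyond the scatter) as a modest move beyond the scatter, removing cyano is expected to take back part of that rise. The estimate therefore means a 3.0-fold lower number from compound 3 to compound 4 (0.48 log units; beyond the scatter) as an expected modest step toward a lower number. For compound 4 the estimated value is 4 nM with an expected range from 1.2 nM to 12 nM in this assay when it is measured.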

Compound 4, half-maximal inhibitory concentration: 4 nM
For compound 4 middle estimate and measured number coincide at the digits printed, within the range that was stated.
By their numbers in this assay, from the lowest: compounds 2 and 4 (each within the scatter of the next); then compound 3; then compound 1.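

In this assay the change from 2-cyanophenyl to 2-methylphenyl gives a 3.0-fold lower number from compound 3 to compound 4 (0.48 log units; beyond the scatter) and so shows that cyano can be replaced at this place, on an aromatic carbon ortho to a large group, with a step beyond the scatter. Methyl in place of chloro gives a 2.0-fold higher number from compound 2 to compound 4 (0.30 log units; within the scatter) and stays within the scatter, so this assay does not separate the two groups, while cyano stands apart from both of them among these three compounds. Nothing given here accounts for this grouping of methyl and chloro apart from cyano.

From the compounds shown here alone, whether a methoxy group, an amine or a longer chain such as ethyl at this place would fall with methyl and chloro or with cyano remains open. The three groups compared here share the same core, so the compounds shown also leave open whether the grouping would hold with the methoxy group that compound 1 carries on its other aromatic ring.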